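Replacing 3-hydroxypropyl with phenyl: notes on compound 4

The compounds below may be only part of what the source reports. "The series", "measured", "known", "first", "only" and "open" are said of these compounds alone.

Values in a functional assay on HeLa cells (Homo sapiens) for antiproliferative activity, read by sulforhodamine B assay; on this read-out lower numbers stand for stronger inhibition of growth and higher numbers for weaker inhibition of growth:
- Compound 1 `CC[C@@H]1O[C@H](COCc2ccccc2)[C@@H](OCc2ccccc2)[C@H](OCc2ccccc2)[C@H]1O` gives 19800 nM
- Compound 2 `C=CC[C@@H]1O[C@H](COCc2ccccc2)[C@@H](OCc2ccccc2)[C@H](OCc2ccccc2)[C@H]1O` gives 26200 nM
- Compound 3 `OCCC[C@@H]1O[C@H](COCc2ccccc2)[C@@H](OCc2ccccc2)[C@H](OCc2ccccc2)[C@H]1O` gives > 50000 nM, a limit and not a number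

Compound 3 stands at the limit of > 50000 nM in this assay, at which 1 of the 3 values shown sits. The next compound, compound 4 `O[C@@H]1[C@@H](OCc2ccccc2)[C@H](OCc2ccccc2)[C@@H](COCc2ccccc2)O[C@H]1c1ccccc1`, carries phenyl in place of 3-hydroxypropyl on a saturated ring carbon, next to the ring oxygen: phenyl in place of 3-hydroxypropyl on a saturated ring carbon.

Going by the values given here, no measured compound has phenyl at this place, so no measured step gives this change directly. The nearest evidence comes from the chain changes on the same ring carbon. Among these, a 1.3-fold higher number from compound 1 to compound 2 (0.12 log units; within the scatter). A larger change appears with the terminal hydroxy group of compound 3: an at least 2.5-fold higher number from compound 1 to compound 3 (0.40 log units; beyond the scatter). The remaining step is an at least 1.9-fold higher number from compound 2 to compound 3 (0.28 log units; that floor lies within the scatter). Compound 4 lacks 3-hydroxypropyl, and so do the two compounds with numerical values: compound 1 gives 19800 nM and compound 2 gives 26200 nM. From the compounds shown here alone, on that basis, compound 4 is expected to fall near these two compounds, although phenyl is untested and a second limit remains possible. A modest move toward a lower number in this assay is expected: an at least 2.0-fold lower number from compound 3 to compound 4 (0.30 log units; that floor lies within the scatter). The estimate for compound 4 is 25000 nM, with an expected range of 10000 nM to 50000 nM.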

Compound 4, concentration for 50% growth inhibition: > 50000 nM
Compound 4: only a limit was reported; the forecaster's own chance of this, stated with the estimate: 30%; middle value at least 2.0-fold (0.30 log units) from the limit.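

In this assay compound 4 gives > 50000 nM, a limit and not a number, so a group without a hydroxy group can also end in a limit at this saturated ring carbon next to the ring oxygen, which compound 3 alone could not show. Against the short chains, phenyl in place of ethyl gives an at least 2.5-fold higher number from compound 1 to compound 4 (0.40 log units; beyond the scatter), a step beyond the scatter, while phenyl in place of allyl gives an at least 1.9-fold higher number from compound 2 to compound 4 (0.28 log units; that floor lies within the scatter), whose floor stays within the scatter, so only the first of these two changes is established as a real loss of growth inhibition. The step between compound 3 and compound 4 cannot be read, and the two compounds share one reported end point: the limit of > 50000 nM in this assay, at which 2 of the 4 values shown sit.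

No order between phenyl and 3-hydroxypropyl can be given from the compounds shown, and compound 1 and compound 2 remain the only ones with numerical values. Also open, from the compounds shown here alone, is how an amine, a carboxylic acid, a benzyl group or a longer chain on the same ring carbon would compare with ethyl and allyl.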